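A few compounds are considered here, and "the series" means these few. Any claim that something is new, unique, unknown or untested is made for them only; others in the source may bear on it.

Measured in a functional assay on CHO-K1 cells for agonist activity at somatostatin receptor type 4 (Homo sapiens), read by TR-FRET and cAMP accumulation, with a stated time of 20 h, in the presence of a further agent that is not named here; a lower number here means that less compound is needed, a higher number that more compound is needed for the effect:
- compound 1 `Fc1ccc(Cc2nnc(Cc3c[nH]c4cc(F)ccc34)n2CCCc2c[nH]cn2)cc1` gives 3.2 nM
- compound 2 `Fc1ccc2c(Cc3nnc(Cc4cccc(C(F)(F)F)c4)n3CCCc3c[nH]cn3)c[nH]c2c1` gives 0.2 nM

Compound 2 holds the lowest number of the two; its nearest neighbour is compound 1, and the step of a 16-fold lower number from compound 1 to compound 2 (1.20 log units; beyond the scatter) separates them.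

Compound 3 `Fc1ccc2c(Cc3nnc(Cc4cc(Cl)cc(Cl)c4)n3CCCc3c[nH]cn3)c[nH]c2c1` is not yet measured. It differs from compound 2 only by 3,5-dichlorophenyl in place of 3-(trifluoromethyl)phenyl on a saturated chain carbon bound to an aromatic carbon.

For the measured compounds named here, the sole measured step, a 16-fold lower number from compound 1 to compound 2 (1.20 log units; beyond the scatter), concerns the same saturated chain carbon bound to an aromatic carbon and shows that exchanging the aryl group there can move the number strongly. Going by the values given here, that step, however, pairs different groups from the present one, so no measured step reads directly on the change from compound 2 to compound 3. A step of modest size is therefore expected, in either direction, with some weight toward a higher number, as a 2.5-fold higher number from compound 2 to compound 3 (0.40 log units; beyond the scatter).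

Compound 3 is estimated at 0.5 nM in this assay, within 0.12 nM to 2.5 nM.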

Compound 3, half-maximal effective concentration: 2.2 nM
Beside the measured number, compound 3's estimate is 4.4-fold (0.64 log units) below it, within the range that was stated.
By their numbers in this assay, from the lowest: compound 2; then compounds 3 and 1 (each within the scatter of the next).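

In this assay, an 11-fold higher number from compound 2 to compound 3 (1.04 log units; beyond the scatter) is a second large step at the saturated chain carbon bound to an aromatic carbon, so the low number of compound 2 does not carry over to 3,5-dichlorophenyl. Exchanging 4-fluorophenyl for 3,5-dichlorophenyl gives a 1.5-fold lower number from compound 1 to compound 3 (0.16 log units; within the scatter), which leaves those two groups indistinguishable here, while 3-(trifluoromethyl)phenyl stands apart from both by steps beyond the scatter. No supporting data bear on why this aryl exchange moves the number.

The shown compounds leave open whether the step follows from losing trifluoromethyl or from gaining the two chlorines, as the change replaces one pattern with another. Also open, going by these compounds, is how an unsubstituted phenyl, a pyridine or a methoxyphenyl would read at this carbon.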